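The compounds below may be only part of what the source reports. "The series", "measured", "known", "first", "only" and "open" are said of these compounds alone.

Compound 1 `C=C1CC[C@@H]2[C@](C)(CCC[C@]2(C)C(=O)OC)[C@H]1CCc1ccc2c(OC)ccc(OC)c2c1`: > 6700 nM
Compound 2 `C=C1CC[C@@H]2[C@](C)(CCC[C@]2(C)C(=O)OC)[C@]1(O)CCc1ccc2c(OC)ccc(OC)c2c1`: > 21500 nM
Compound 3 `COC(=O)[C@@]1(C)CCC[C@]2(C)C(CCc3ccc4c(OC(C)=O)ccc(OC(C)=O)c4c3)=C(C)CC[C@@H]12`: 240 nM

Three of these compounds have been tested in a functional assay on HT-29 cells (Homo sapiens) for cytotoxicity, read by sulforhodamine B assay, with a stated time of 72 h; a higher number here means a weaker inhibitor of growth, a lower number a stronger inhibitor of growth. For compound 1 the result is a limit of the assay, > 6700 nM. For compound 2 the result is likewise a limit, > 21500 nM. Going by the values given here, compound 3 gives 240 nM, the only real number among the three. The change from compound 1 to compound 2 is hydroxy in place of hydrogen on a saturated ring carbon; its step, a step that the two limits leave unreadable from compound 1 to compound 2, cannot be sized because of the limit of > 6700 nM in this assay, at which 1 of the 3 values shown sits, and (the limit of > 21500 nM in this assay, at which 1 of the 3 values shown sits). The difference between the core of compound 1 and the core of compound 3 is not broken down here.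

Compound 4 `COC(=O)[C@@]1(C)CCC[C@]2(C)C(CCc3ccc4c(OC(C)=O)ccc(OC(C)=O)c4c3)=C(C)[C@@H](O)C[C@@H]12` has not yet been measured. It differs from compound 3 by hydroxy in place of hydrogen on a saturated ring carbon. Among the compounds with values here, this is the same kind of change as the one from compound 1 to compound 2, but the surroundings are not identical: in compound 4 the carbon is next to the ring atom that bears a methyl group, two ring bonds from the ring atom that bears a fused ring and from the ring atom that bears a large group, and three ring bonds from the ring atom that bears a fused ring and from the ring atom that bears a methyl group, whereas in compound 2 it is next to the ring atom that bears a fused ring and next to the ring atom that bears a methyl group. The measured example gives no size for this change, so the expectation rests on compound 3 alone. Compound 4 is expected to give about 450 nM in this assay, within 120 nM to 2000 nM. The expected step of a 1.9-fold higher number from compound 3 to compound 4 (0.27 log units; within the scatter) is a modest one, estimated with wide uncertainty since compound 3 at 240 nM is the only anchor.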

Compound 4, concentration for 50% growth inhibition: 4800 nM
Beside the measured number, compound 4's estimate is 11-fold (1.03 log units) below it; the measured number lies above the stated range.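

In this assay, hydroxy in place of hydrogen on a saturated ring carbon gives a 20-fold higher number from compound 3 to compound 4 (1.30 log units; beyond the scatter), so on this core the change clearly weakens growth inhibition. The same kind of change, made at a different ring carbon on a different core, links compound 1 and compound 2, but that step cannot be read and offers no size to compare, because the result for compound 1 is a limit of the assay: the limit of > 6700 nM in this assay, at which 1 of the 4 values shown sits. The result for compound 2 is also a limit of the assay, so the series shows one sized step on one core and no evidence that the effect carries over, or fails to carry over, to the other core: the limit of > 21500 nM in this assay, at which 1 of the 4 values shown sits.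

Among the compounds shown, only one ring carbon on the core of compound 3 carries a hydroxy, which leaves open whether the loss follows the hydroxy itself or that particular place, and no reason for the loss is given. Also open, as far as these compounds go, is how an amine or a fluorine at that same ring carbon, in place of the hydroxy, would compare with compound 3 at 240 nM.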